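The source may hold more compounds than are shown below. What is called first, only, known or untested is meant among the compounds shown, and "the series" means these compounds.

Measured compounds: compound 1 `Oc1cccc(-c2cc(-c3ccc(Cl)cc3)nc(-c3ccco3)c2)c1` with 10500 nM in a functional assay on T47D cells (Homo sapiens) for cytotoxicity, read by CCK-8 assay and cell counting, with a stated time of 2 days; on this read-out lower numbers stand for stronger inhibition and higher numbers for weaker inhibition; compound 2 `Oc1cccc(-c2cc(-c3ccco3)nc(-c3ccccc3Cl)c2)c1` with 2010 nM; compound 3 `Oc1cccc(-c2cc(-c3ccsc3)nc(-c3ccccc3Cl)c2)c1` with 2440 nM.

Within this set compound 1 gives the highest number; the step from it to compound 2, a 5.2-fold lower number from compound 1 to compound 2 (0.72 log units; beyond the scatter), moves chlorine on the chlorophenyl group, and compound 3 shows a 1.2-fold higher number from compound 2 to compound 3 (0.08 log units; within the scatter) for a swap of five-membered rings on the core. Compound 4 `Oc1cccc(-c2cc(-c3ccc(Cl)cc3)nc(-c3cccnc3)c2)c1` differs from compound 1 by pyridin-3-yl in place of furan-2-yl on an aromatic carbon. For the measured compounds named here, the only step that resembles this change, a 1.2-fold higher number from compound 2 to compound 3 (0.08 log units; within the scatter), stayed within the scatter, so the heteroaryl swap is expected to shift this assay little in either direction. Compound 4 is therefore estimated at 9000 nM, between 3000 nM and 27000 nM, a step of a 1.2-fold lower number from compound 1 to compound 4 (0.07 log units; within the scatter).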

Compound 4, half-maximal inhibitory concentration: 18100 nM
Beside the measured number, compound 4's estimate is 2.0-fold (0.30 log units) below it; low and high end bracket the measured number.
By their numbers in this assay, from the lowest: compounds 2 and 3 (each within the scatter of the next); then compounds 1 and 4 (each within the scatter of the next).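

In this assay, the aromatic carbon next to the ring nitrogen takes a six-membered ring as well as a five-membered one: pyridin-3-yl for furan-2-yl gives a 1.7-fold higher number from compound 1 to compound 4 (0.24 log units; within the scatter). The earlier heteroaryl swap joined two five-membered rings beside a 2-chlorophenyl group, whereas this one changes ring size beside a 4-chlorophenyl group and also stays within the scatter. No available evidence explains this result.

Still open, on these data alone, is whether pyridin-3-yl behaves the same way beside a 2-chlorophenyl group. As far as these compounds go, it is also open how a piperidine or a carboxylic acid would read at this carbon.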